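The source may report more compounds than this note shows. Statements on the series, on what has been measured and on what is new or still open speak of the compounds shown alone.

Compound 3 `Fc1ccc(C2=NN(C3=NC(c4ccccc4)CS3)C(c3cccc4ccccc34)C2)cc1` gives the highest number of the three measured compounds in a functional assay on BGC-823 cells (Homo sapiens) for inhibition, read by CCK-8 assay, with a stated time of 48 h (on this read-out lower numbers stand for stronger inhibition and higher numbers for weaker inhibition), where compound 3 gives 22700 nM. Among the measured compounds shown here, its nearest neighbour is compound 1 `c1ccc(C2=NN(C3=NC(c4ccccc4)CS3)C(c3cccc4ccccc34)C2)cc1`, which in this assay gives 14300 nM; the step of a 1.6-fold higher number from compound 1 to compound 3 (0.20 log units; within the scatter) is the only single-change step among the measured compounds. Furthest from it lies compound 2 `Cc1ccc(C2=NN(C3=NC(c4ccccc4)CS3)C(c3ccc4ccccc4c3)C2)cc1`, which in this assay gives 8940 nM, a number beyond the scatter from that of compound 3; compound 2 differs from compound 3 in more than one place, so its value alone can be read, not a step.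

Compound 4 `Cc1ccc(C2=NN(C3=NC(c4ccccc4)CS3)C(c3cccc4ccccc34)C2)cc1` differs from compound 3 by methyl in place of fluoro on an aromatic carbon. For the measured compounds named here, no measured step exchanges fluoro for methyl. The step from compound 1 to compound 3 shows only that removing the fluoro gave a number within the scatter, so the return to a hydrogen-like position is not expected to move the read-out much on its own. Compound 2 carries a methyl on that ring, yet its second difference leaves its value an uncertain guide. Compound 4 is therefore expected to change by a 2.1-fold lower number from compound 3 to compound 4 (0.31 log units; beyond the scatter) in this assay, a step at the edge of the scatter and towards a lower number. The estimate for compound 4 is 11000 nM, between 5500 nM and 24000 nM.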

Compound 4, half-maximal inhibitory concentration: 13300 nM
Beside the measured number, compound 4's estimate is 1.2-fold (0.08 log units) below it; measured number inside the range.
By their numbers in this assay, from the lowest: compounds 2, 4, 1 and 3 (each within the scatter of the next, the first and the last beyond it).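

In this assay the step of a 1.7-fold lower number from compound 3 to compound 4 (0.23 log units; within the scatter) exchanges the fluoro of the 4-fluorophenyl for a methyl, and the step of a 1.1-fold lower number from compound 1 to compound 4 (0.03 log units; within the scatter) puts that methyl in place of hydrogen on the same aromatic carbon, para to a large group. Hydrogen, fluoro and methyl can now all be read at this position, and no step among them leaves the scatter, so the three are not told apart in this assay. Among the compounds shown here, the result also gives the first single-change reading for compound 2, since the step of a 1.5-fold higher number from compound 2 to compound 4 (0.17 log units; within the scatter), with naphthalen-1-yl in place of naphthalen-2-yl on a saturated ring carbon and the methyl held fixed, also lies within the scatter, and no evidence is at hand on what lies behind these small steps.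

The compounds shown leave open whether a group of another kind on this aromatic carbon, such as an amine, a carboxylic acid or a longer chain, would carry the number beyond the scatter. On these data alone, it also remains open whether the exchange of the two naphthalenyl groups reads the same with hydrogen or fluoro in place of the methyl.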